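This account rests on a few compounds, and the source may have more. Where it says the series, first, only, none or still open, it means among the compounds named here.

In an ADME assay on MT4 cells (Homo sapiens) for cytotoxicity, read by MTT assay, with a stated time of 5 days (a higher number here means that more compound is tolerated, a lower number that less compound is tolerated), compound 2 `Cc1cc(C)c(Oc2cc(Nc3ccc(C#N)cc3)[nH]c(=O)c2Br)c(C)c1` gives > 294000 nM, which is only a limit of the assay and not an exact number. Compound 3 `Cc1cc(C#N)cc(C)c1Oc1cc(Nc2ccc(C#N)cc2)[nH]c(=O)c1Br` has cyano in place of methyl on an aromatic carbon of compound 2: cyano in place of methyl on an aromatic carbon. Compound 1 `Cc1cc(C#N)cc(C)c1Oc1cc(Nc2ccc(C#N)cc2)[nH]c(=O)c1`, which also carries a cyano group, gives 25000 nM, and this points to less compound being tolerated in compound 3. The expected change is a drop clearly beyond the usual scatter: an at least 4.9-fold lower number from compound 2 to compound 3 (0.69 log units; beyond the scatter). For compound 3 the estimated value is 60000 nM, with an expected range of 15000 nM to 250000 nM.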

Compound 3, half-maximal cytotoxic concentration: > 287000 nM
Compound 3 ended at the assay's limit (the forecaster's own chance of this, stated with the estimate: 25%); at least 4.7-fold (0.67 log units) between middle value and limit.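

Carrying a cyano group does not by itself go with a low number: in this assay, bromo in place of hydrogen on an aromatic carbon gives an at least 11-fold higher number from compound 1 to compound 3 (1.05 log units; beyond the scatter). Compound 2 and compound 3 both end at limits, so the step of cyano in place of methyl cannot be read. At this position, the swap therefore shows no measurable loss of tolerance, though a smaller difference could lie hidden past those limits.

On these data alone, how much compound these bromo compounds tolerate beyond their limits stays open. So does whether an amine or a carboxylic acid in place of the cyano group would also reach a limit.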